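The compounds below may be only part of what the source reports. "The series", "measured", "known", "first", "only" and "open" are said of these compounds alone.

Measured compounds in an assay on cells for inhibition of Amine oxidase [flavin-containing] B (Homo sapiens), read by fluorescence and Amplex Red, using microsomes, with a stated time of 15 min; a higher number here means a weaker inhibitor, a lower number a stronger inhibitor:
- compound 1, `Cc1ccc2occ(C(=O)Nc3ccccc3)c(=O)c2c1`: 21.4 nM
- compound 2, `Cc1cccc(NC(=O)c2coc3ccc(C)cc3c2=O)c1`: 17.1 nM
- compound 3, `Cc1ccc2occ(C(=O)Nc3ccc(Cl)cc3)c(=O)c2c1`: 45.4 nM

Compound 3 gives the highest number of the three. Its nearest neighbour is compound 1, with a 2.1-fold higher number from compound 1 to compound 3 (0.33 log units; beyond the scatter) on adding chloro to the phenyl on the amide nitrogen; against compound 2 the gap is wider, a 2.7-fold higher number from compound 2 to compound 3 (0.42 log units; beyond the scatter). Compound 1 and compound 2 themselves sit within the scatter of each other, a 1.3-fold lower number from compound 1 to compound 2 (0.10 log units; within the scatter).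

Compound 4, `Cc1ccc2occ(C(=O)Nc3ccc(O)cc3)c(=O)c2c1`, is still to be measured in this assay. The change from compound 3 is hydroxy in place of chloro on an aromatic carbon. Within the data shown here, the only measured step that bears directly on it is the reverse of a 2.1-fold higher number from compound 1 to compound 3 (0.33 log units; beyond the scatter): taking the chloro off returns to the number of compound 1, and that step is modest. Among the measured compounds shown here, no measured compound carries a hydroxy or any other donor group on that phenyl, so the effect of the incoming hydroxy itself has no precedent.

The expectation for compound 4 is therefore a modest fall back toward compound 1, a 1.8-fold lower number from compound 3 to compound 4 (0.26 log units; within the scatter), with wide uncertainty because the hydroxy is new to the series. Compound 4 is estimated at 25 nM, within a range of 9 nM to 70 nM.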

Compound 4, half-maximal inhibitory concentration: 513 nM
Beside the measured number, compound 4's estimate is 21-fold (1.31 log units) below it; measured number outside the range, above it.
By their numbers in this assay, from the lowest: compounds 2 and 1 (each within the scatter of the next); then compound 3; then compound 4.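

In this assay, among these compounds, the position para to a large group proves far more sensitive than the earlier compounds suggested: adding chloro there gave only a 2.1-fold higher number from compound 1 to compound 3 (0.33 log units; beyond the scatter), whereas adding hydroxy gave a 24-fold higher number from compound 1 to compound 4 (1.38 log units; beyond the scatter). Exchanging chloro for hydroxy leaves the heavy-atom count unchanged but adds a hydrogen-bond donor and a hydrogen-bond acceptor, and it gives an 11-fold higher number from compound 3 to compound 4 (1.05 log units; beyond the scatter), so heavy-atom count alone does not track the number at this position. The earlier spread within the series was also narrow, while replacing 3-methylphenyl with 4-hydroxyphenyl gives a 30-fold higher number from compound 2 to compound 4 (1.48 log units; beyond the scatter), the widest step shown, although no information here accounts for the loss with hydroxy.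

The compounds shown leave open whether the large step goes with the hydroxy hydrogen specifically, which a methoxy or an amine at the same position could help separate. They also leave open whether hydroxy has the same effect elsewhere on the ring, such as where compound 2 carries its methyl, and whether a fluoro at the para position would stay close to chloro.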